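The compounds below may be only part of what the source reports. "The series", "measured", "known", "first", "only" and "open" are said of these compounds alone.

Compound 1 `O=c1[nH]cc(S(=O)(=O)Nc2cccc(-c3cn(-c4ccccc4F)nn3)c2)c(=O)[nH]1` carries a 2-fluorophenyl on an aromatic nitrogen. In a functional assay on HepG2 cells (Homo sapiens) for antiproliferative activity, read by MTT assay, with a stated time of 24 h (a higher number here means a weaker inhibitor, a lower number a stronger inhibitor), compound 1 gives 13900 nM. Compound 2 `O=c1[nH]cc(S(=O)(=O)Nc2cccc(-c3cn(-c4cccc(F)c4)nn3)c2)c(=O)[nH]1` differs from it by 3-fluorophenyl in place of 2-fluorophenyl on an aromatic nitrogen, and in this assay compound 2 reaches only the limit of the assay, > 20000 nM. The measured step is an at least 1.4-fold higher number from compound 1 to compound 2 (0.15 log units; that floor lies within the scatter). Compound 3 `O=c1[nH]cc(S(=O)(=O)Nc2ccc(-c3cn(-c4ccccc4F)nn3)cc2)c(=O)[nH]1` keeps the 2-fluorophenyl of compound 1, but the difference between the two cores is not broken down here. In this assay compound 3 likewise returns a limit, > 20000 nM. Compound 4 `O=c1[nH]cc(S(=O)(=O)Nc2ccc(-c3cn(-c4cccc(F)c4)nn3)cc2)c(=O)[nH]1` differs from compound 3 by 3-fluorophenyl in place of 2-fluorophenyl on an aromatic nitrogen, the same change as from compound 1 to compound 2. Because the limit of > 20000 nM in this assay, at which 2 of the 3 values shown sit, already holds compound 3, the same change is expected to leave compound 4 at that limit as well, with the step estimated as a step that the limit leaves unreadable from compound 3 to compound 4. Compound 4 is therefore estimated at 35000 nM, ranging from 18000 nM to 90000 nM.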

Compound 4, half-maximal inhibitory concentration: > 20000 nM
Compound 4 was reported as a limit; the forecaster's own chance of this, stated with the estimate: 85%; the middle value lies beyond the limit too.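

Compound 3 and compound 4 both return only a limit in this assay, so no step between them can be read: the limit of > 20000 nM in this assay, at which 3 of the 4 values shown sit.

The compounds shown leave open whether 3-fluorophenyl in place of 2-fluorophenyl changes anything on the core of compound 3.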